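Swapping trifluoromethyl for methylsulfonyl on a shared core

The source may report more compounds than this note shows. Statements on the series, on what has been measured and on what is new or still open speak of the compounds shown alone.

Measured compounds:
Compound 1, `CNc1nc(NCCCN(C)C)c2sc(-c3ccc(C(F)(F)F)cc3)cc2n1`, gives 2.07 h in an ADME assay (liver) for metabolic stability, with Liver microsome (Homo sapiens) as the target, read by LC-MS, using microsomes, tested at 1 uM; a lower number here means that the compound disappears faster, a higher number that the compound lasts longer.
Compound 2, `CNc1nc(NCCCN(C)C)c2sc(-c3ccc(C(F)(F)F)cc3Cl)cc2n1`, gives 2.17 h in this assay.
Compound 3, `CNc1nc(NCCCN(C)C)c2sc(-c3cccc4cnccc34)cc2n1`, gives 0.422 h in this assay.

Among these three, compound 1 stands second highest. Its nearest neighbour is compound 2, and the step of a 1.0-fold higher number from compound 1 to compound 2 (0.02 log units; within the scatter) lies within the scatter, so the two cannot be told apart. Compound 3, which carries a different aromatic group on the shared core, lies furthest away with a much lower value than compound 1.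

Compound 4, `CNc1nc(NCCCN(C)C)c2sc(-c3ccc(S(C)(=O)=O)cc3)cc2n1`, has not yet been measured. It differs from compound 1 in one place: methylsulfonyl in place of trifluoromethyl on an aromatic carbon.

Among the measured compounds shown here, no measured step changes the same group. For the measured compounds named here, the only single-place step available, from compound 1 to compound 2, adds a chloro to the same ring and leaves the half-life essentially unchanged. Compound 3 shows that a larger change to the aromatic group can shift the value strongly, but that change is of another kind. The expectation for compound 4 therefore rests on weak footing and is estimated as a step of a 1.2-fold higher number from compound 1 to compound 4 (0.08 log units; within the scatter) in this assay, not clearly beyond the scatter in either direction. Compound 4 is thus expected to give about 2.5 h, with a range from 1 h to 6 h.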

Compound 4, half-life: 1.92 h
For compound 4 the middle estimate is 1.3-fold (0.11 log units) above the measured one; the range from low to high includes it.
By their numbers in this assay, from the lowest: compound 3; then compounds 4, 1 and 2 (each within the scatter of the next).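

In this assay, methylsulfonyl in place of trifluoromethyl on an aromatic carbon, para to a large group, gives a 1.1-fold lower number from compound 1 to compound 4 (0.03 log units; within the scatter), so the two groups cannot be told apart by half-life. The earlier single-place step only added a chloro to this ring, whereas this one replaces the group at this place itself: a group with two hydrogen-bond acceptors enters where one with none leaves, the count of heavy atoms stays the same, and the read-out does not separate the pair. No measurement at hand accounts for this result.

From the compounds shown here alone, this single exchange of two groups does not show how widely the place accepts change, and it remains open whether an amine or a carboxylic acid there would also give a half-life that cannot be told apart from that of compound 1. Going by these compounds, it is equally open whether methylsulfonyl would read alike in the setting of compound 2, which carries a chloro on the same ring.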